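The source may report more compounds than this note shows. Statements on the series, on what has been measured and on what is new or still open speak of the compounds shown alone.

Compound 1, with the structure `CNc1nc(NC2(C#N)CCCCC2)nc(-n2ccnc2)n1`, was tested in an ADME assay on microsomes from liver (Rattus norvegicus) for metabolic stability (on this read-out lower numbers stand for slow clearance and higher numbers for fast clearance), and there compound 1 gives 52 mL/min/kg. One other compound measured in this assay shares part of its build: compound 2, with the structure `C#CC(CC)(CC)Nc1nc(NC)nc(-n2cncn2)n1`, which gives 22 mL/min/kg. Of these two numbers, compound 1 has the higher one, and its gap to compound 2 lies beyond the usual scatter of repeated measurements, so the two compounds really do differ in how fast they are cleared.

The next compound to follow is compound 3, with the structure `CNc1nc(NC2(C#N)CCCCC2)nc(SC)n1`. It is compound 1 with one change: methylsulfanyl in place of 1H-imidazol-1-yl on an aromatic carbon. Among the compounds with values here, no step between two measured compounds shows what this exchange does, so the expectation for compound 3 rests only on compound 1 and the size of the change. The expected step in this assay is a 1.3-fold lower number from compound 1 to compound 3 (0.11 log units; within the scatter), a modest move downward that stays inside the usual scatter. Compound 3 is therefore estimated at 40 mL/min/kg, with a likely range from 18 mL/min/kg to 90 mL/min/kg.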

Compound 3, clearance: 579 mL/min/kg
Compound 3: middle estimate off by 14-fold (1.16 log units), on the low side; measured number above the stated range.
By their numbers in this assay, from the lowest: compound 2; then compound 1; then compound 3.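

Within the data shown here, at this place on the shared core, on an aromatic carbon between two ring nitrogen atoms, the exchange of 1H-imidazol-1-yl for methylsulfanyl gives the first direct reading of what this position does in this assay: an 11-fold higher number from compound 1 to compound 3 (1.05 log units; beyond the scatter). The step is large and lies beyond the scatter, so with the rest of compound 1 left as it is, the group at this one position is enough on its own to change clearance strongly. No measurement shown here explains the size of this jump.

Two things change together in this single step, as a five-membered aromatic ring leaves and a small sulfur-bearing group with no ring enters, so the pair cannot tell which of the two matters more. Among these compounds, also open are how a methoxy group or a plain amine at this same position would compare, and whether methylsulfanyl would give a step of similar size on a compound with a different side chain from the one in compound 1.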